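The source may hold more compounds than are shown below. What is called first, only, known or untested is meant among the compounds shown, and "the series" means these compounds.

Compound 1 `COc1ccc(-c2cnc(NC(=O)c3ccc(O)cc3)n2C)cc1`: in a toxicity assay on THP-1 cells (Homo sapiens) for inhibition (a lower number here means that less compound is tolerated, a higher number that more compound is tolerated), compound 1 gives > 100000 nM, a limit of the assay rather than a number.
Compound 2 `Cn1c(-c2ccccc2)cnc1NC(=O)c1ccc(Cl)cc1`: in this assay compound 2 gives > 100000 nM, again a limit.
Compound 3 `COc1ccc(-c2cnc(NC(=O)c3ccc([N+](=O)[O-])cc3)n2C)cc1`: in this assay compound 3 gives > 100000 nM, also a limit.

Compound 1 therefore stands only at a limit in this assay, and so do the other two values shown (the limit of > 100000 nM in this assay, at which 3 of the 3 values shown sit). Among the measured compounds shown here, the single step between measured compounds that differ in one place, a step that the two limits leave unreadable from compound 1 to compound 3, cannot be read, since both ends sit at the limit.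

Compound 4 `COc1ccc(-c2cnc(NC(=O)c3cccc(Br)c3)n2C)cc1` differs from compound 1 as follows: 3-bromophenyl in place of 4-hydroxyphenyl on a carbonyl carbon

For the measured compounds named here, no measured step bears on this exchange in a readable way: the only step available, a step that the two limits leave unreadable from compound 1 to compound 3, is unreadable, and compound 2 has no step to any other compound, its value merely showing the same limit. With every value shown at the limit (the limit of > 100000 nM in this assay, at which 3 of the 3 values shown sit), the expectation for compound 4 is that it, too, is tolerated up to the limit of this assay. Compound 4 is estimated at 150000 nM, within 60000 nM to 400000 nM. The expected step is a step that the limit leaves unreadable from compound 1 to compound 4, i.e. none readable beyond the scatter.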

Compound 4, half-maximal cytotoxic concentration: > 100000 nM
Compound 4 was reported as a limit; the forecaster's own chance of this, stated with the estimate: 85%; the middle value is on the limit's open side.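

Compound 1 and compound 4 both stand only at a limit in this assay, so no step can be read for the exchange of 4-hydroxyphenyl for 3-bromophenyl: the limit of > 100000 nM in this assay, at which 4 of the 4 values shown sit. The compounds shown leave open at what concentration, if any, any member of this series becomes cytotoxic.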